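The source may hold more compounds than are shown below. What is called first, only, known or untested is meant among the compounds shown, and "the series" means these compounds.

Compound 1 `N#CC1=C(N)Oc2c(N)cc3nc4ccccc4nc3c2C12C(=O)N(Cc1cnnn1-c1ccc(F)cc1)c1ccccc12`: in an ADME assay on L02 cells (Homo sapiens) for antiproliferative activity, read by MTT assay, with a stated time of 48 h (a higher number here means a weaker inhibitor, a lower number a stronger inhibitor), compound 1 gives > 50000 nM, which is a limit of the assay and not a number.
Compound 2 `CCOc1ccccc1-n1nncc1CN1C(=O)C2(C(C#N)=C(N)Oc3c(N)cc4nc5ccccc5nc4c32)c2ccccc21`: in this assay compound 2 gives > 50000 nM, again a limit rather than a number.
Compound 3 `Cc1ccc(-n2nncc2CN2C(=O)C3(C(C#N)=C(N)Oc4c(N)cc5nc6ccccc6nc5c43)c3ccccc32)cc1C`: in this assay compound 3 gives > 50000 nM, also a limit.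

All three measured values sit at the same point, (the limit of > 50000 nM in this assay, at which 3 of the 3 values shown sit). Compound 3 therefore stands only at a limit; nothing in the numbers places it above or below compound 1 or compound 2. The steps a step that the two limits leave unreadable from compound 1 to compound 2, a step that the two limits leave unreadable from compound 1 to compound 3 and a step that the two limits leave unreadable from compound 2 to compound 3 are each unreadable, as both ends of every pair are limits. What the data show is that three different aryl groups on the aromatic nitrogen all leave the read-out at the limit.

Compound 4 `N#CC1=C(N)Oc2c(N)cc3nc4ccccc4nc3c2C12C(=O)N(Cc1cnnn1-c1ccc(Cl)cc1[N+](=O)[O-])c1ccccc12` differs from compound 3 by 4-chloro-2-nitrophenyl in place of 3,4-dimethylphenyl on an aromatic nitrogen. For the measured compounds named here, no measured step gives a readable size or direction, so the only guide is that every variation at this position so far has stayed at the limit. The step that the limit leaves unreadable from compound 3 to compound 4 is therefore expected to be none beyond the scatter, most likely with another limit reported. Compound 4 is estimated at 70000 nM, with a range from 25000 nM to 250000 nM.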

Compound 4, half-maximal inhibitory concentration: > 50000 nM
Compound 4: only a limit was reported; the forecaster's own chance of this, stated with the estimate: 85%; the middle value is on the limit's open side.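

The steps from compound 1, compound 2 and compound 3 to compound 4 cannot be read, since both ends of each pair are limits: the limit of > 50000 nM in this assay, at which 4 of the 4 values shown sit. Going by these compounds, what stays open is whether any aryl group on the aromatic nitrogen of the shared core brings the read-out off the limit, and how far these four compounds lie from one another.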